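The compounds below may be only part of what the source reports. "The series", "measured", "known", "first", "only" and "open" are said of these compounds alone.

Compound 1 `Cc1ccccc1Oc1ccc(C#N)cc1S(=O)(=O)NC(=O)NC(C)(C)C`: 1470 nM
Compound 2 `Cc1cccc(Oc2ccc(C#N)cc2S(=O)(=O)NC(=O)NC(C)(C)C)c1`: 690 nM

In a functional assay on HEK293 cells for antagonist activity at thromboxane A2 receptor (Homo sapiens), read by fluorescence and calcium flux (on this read-out higher numbers stand for weaker inhibition and lower numbers for stronger inhibition), compound 2 gives 690 nM, the lowest of the two numbers; the nearest is compound 1 with 1470 nM. Compound 3 `Cc1ccc(Oc2ccc(C#N)cc2S(=O)(=O)NC(=O)NC(C)(C)C)cc1` is not yet measured; the change from compound 2 to compound 3 is 4-methylphenyl in place of 3-methylphenyl on an oxygen on an aromatic ring. For the measured compounds named here, only one measured step bears on it, a 2.1-fold lower number from compound 1 to compound 2 (0.33 log units; beyond the scatter), and it was modest. Shifting the methyl once more is untested, so a step of similar size or none beyond the scatter is expected: a 1.2-fold lower number from compound 2 to compound 3 (0.06 log units; within the scatter). Compound 3 is therefore estimated at 600 nM, within 200 nM to 1800 nM.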

Compound 3, half-maximal inhibitory concentration: 680 nM
The estimate for compound 3 lay 1.1-fold (0.05 log units) below the measured number, within the range that was stated.
By their numbers in this assay, from the lowest: compounds 3 and 2 (each within the scatter of the next); then compound 1.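

In this assay the shift from 3-methylphenyl to 4-methylphenyl gives a 1.0-fold lower number from compound 2 to compound 3 (0.01 log units; within the scatter) and so makes no readable difference, while a 2.2-fold lower number from compound 1 to compound 3 (0.33 log units; beyond the scatter) matches in size the step already seen on leaving 2-methylphenyl. Among these three groups, then, only 2-methylphenyl stands apart. Nothing available here explains this. The compounds shown leave open how an unsubstituted phenyl, a methoxy group, a chlorine or a longer chain such as ethyl would read at this place, and what a second methyl on the same ring would do.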